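Swapping the Aryl Group on an Aromatic Nitrogen

The source may report more compounds than this note shows. Statements on the series, on what has been measured and on what is new or still open speak of the compounds shown alone.

Of the compounds shown here, two have been measured in a functional assay on HepG2 cells (Homo sapiens) for inhibition, read by MTT assay, with a stated time of 72 h; a lower number here means a stronger inhibitor, a higher number a weaker inhibitor. Compound 1 `CCc1ccccc1-n1cc(COc2cccc(NC(=O)Nc3ccc(Cl)c(C(F)(F)F)c3)c2)nn1` gives 3530 nM in this assay, the higher of the two numbers. Compound 2 `O=C(Nc1cccc(OCc2cn(-c3ccc(F)cc3)nn2)c1)Nc1ccc(Cl)c(C(F)(F)F)c1` gives 1350 nM in this assay. Among the compounds with values here, the sole change between them is 4-fluorophenyl in place of 2-ethylphenyl on an aromatic nitrogen, and it brought a 2.6-fold lower number from compound 1 to compound 2 (0.42 log units; beyond the scatter).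

Compound 3 `O=C(Nc1cccc(OCc2cn(-c3ccc(I)cc3)nn2)c1)Nc1ccc(Cl)c(C(F)(F)F)c1` has not yet been measured. Compared with compound 1 it carries 4-iodophenyl in place of 2-ethylphenyl on an aromatic nitrogen. Within the data shown here, the only measured step that bears on this change is the one from compound 1 to compound 2, where a 4-fluorophenyl likewise replaced the 2-ethylphenyl. Because that step was a 2.6-fold lower number from compound 1 to compound 2 (0.42 log units; beyond the scatter), a lower number of similar size is expected for compound 3 in this assay, though the iodine may shift it somewhat either way. Compound 3 is therefore estimated at 1200 nM, with a range from 400 nM to 3500 nM, which would mean a 2.9-fold lower number from compound 1 to compound 3 (0.47 log units; beyond the scatter) as the expected step.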

Compound 3, half-maximal inhibitory concentration: 2690 nM
Beside the measured number, compound 3's estimate is 2.2-fold (0.35 log units) below it; the range from low to high includes it.
By their numbers in this assay, from the lowest: compounds 2, 3 and 1 (each within the scatter of the next, the first and the last beyond it).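

Read in this assay, the 4-iodophenyl group does not clearly repeat the gain seen with 4-fluorophenyl: replacing 2-ethylphenyl on the aromatic nitrogen gives a step within the scatter (a 1.3-fold lower number from compound 1 to compound 3 (0.12 log units; within the scatter)). Exchanging the halogen on the aromatic carbon also stays within the scatter (a 2.0-fold higher number from compound 2 to compound 3 (0.30 log units; within the scatter)), so compound 3 cannot be told apart from either neighbour, and only compound 1 and compound 2 remain separated. With three compounds, this position therefore tolerates iodo in place of fluoro without a clear change, but no explanation for the result is available from measured data.

Still open, from the compounds shown here alone, is whether a 4-chlorophenyl or 4-bromophenyl group would fall with compound 2 or with compound 3. An unsubstituted phenyl and a 4-ethylphenyl group would also be needed to separate the effect of the halogen from that of the ethyl group's place on the ring.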